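Moving the Acid on the Sulfur-Linked Ring

This account rests on a few compounds, and the source may have more. Where it says the series, first, only, none or still open, it means among the compounds named here.

- Compound 1 `CCCCCCCCCCCCOc1ccc(C[S+]([O-])c2cccc(C(=O)O)c2)nc1/C=C/C(=O)O` gives 930 nM
- Compound 2 `COc1ccc(CCCCCCCCOc2ccc(COc3cccc(C(=O)O)c3)[n+]([O-])c2/C=C/C(=O)O)cc1` gives 890 nM

Both compounds were tested in a functional assay on U-937 cells (Homo sapiens) for antagonist activity, read by calcium flux; on this read-out lower numbers stand for stronger inhibition and higher numbers for weaker inhibition. Compound 1 has the higher of the two numbers, but the gap to compound 2 lies within the usual scatter of repeated measurements, so the two cannot be ranked.

Compound 3 `CCCCCCCCCCCCOc1ccc(C[S+]([O-])c2ccccc2C(=O)O)nc1/C=C/C(=O)O` has not yet been measured. It contains the same atoms as compound 1, joined differently: 2-carboxyphenyl in place of 3-carboxyphenyl on a sulfur whose other neighbours are oxygen and a saturated chain carbon (2-carboxyphenyl in place of 3-carboxyphenyl on a sulfur). The rest of the molecule is unchanged.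

Among the compounds with values here, no measured pair here shows what such a change does, and compound 2 differs from compound 1 in more than one place, so it offers no direct guide. The starting point is therefore compound 1 at 930 nM. A modest loss of inhibition, meaning a higher number, seems more likely than a gain, though this is uncertain. The expected change is a 2.2-fold higher number from compound 1 to compound 3 (0.33 log units; beyond the scatter). For compound 3 the estimated value is 2000 nM, with an expected range of 600 nM to 8000 nM.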

Compound 3, half-maximal inhibitory concentration: 1500 nM
Estimate against measurement, compound 3: 1.3-fold (0.12 log units) above; the range from low to high includes it.
By their numbers in this assay, from the lowest: compounds 2, 1 and 3 (each within the scatter of the next).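

In this assay, putting 2-carboxyphenyl in place of 3-carboxyphenyl on a sulfur whose other neighbours are oxygen and a saturated chain carbon gives a 1.6-fold higher number from compound 1 to compound 3 (0.21 log units; within the scatter). Within the data shown here, this is the first direct reading of this position: the earlier compounds offered no pair that differs in one place, whereas this pair shows that, on the core of compound 1, the two placements of the carboxylic acid cannot be told apart in inhibition. No measurement of any property of these groups is available to bear on this result.

On these data alone, a ring carrying a nitrile or an amide in place of the carboxylic acid would show whether the acid on this ring is needed at all, and that question stays open. As far as these compounds go, the finding also rests on a single pair, so whether it carries over to a different chain on the shared core remains unknown.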